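Triazolopyrimidines at the CRF1 receptor: an ether for an amine

This account rests on a few compounds, and the source may have more. Where it says the series, first, only, none or still open, it means among the compounds named here.

Measured compounds:
compound 1 `CCCCC(CC)Nc1nc(C)nc2c1nnn2-c1c(C)cc(C)cc1C`: 7.6 nM
compound 2 `CCN(c1nc(C)nc2c1nnn2-c1ccc(C(C)C)cc1Br)C(COC)COC`: 123 nM
compound 3 `CCCCN(CC)c1nc(C)nc2c1nnn2-c1ccc(S(C)(=O)=O)cc1Br`: 100 nM

Of the compounds shown here, three sharing one core have been tested in an in vitro assay on 293-EBNA cells for binding affinity to corticotropin-releasing factor receptor 1 (Homo sapiens); a higher number here means a weaker inhibitor, a lower number a stronger inhibitor. Compound 1 gives the lowest number of the three, and in this assay compound 2 gives the highest. The gap between compound 2 and compound 3 is within the scatter, so these two cannot be told apart; the gap between compound 2 and compound 1 is beyond the scatter, and compound 1 is clearly the stronger binder of that pair.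

Compound 4 `CCC(CC)Oc1nc(C)nc2c1nnn2-c1ccc(C(C)C)cc1Br` has not yet been measured. It keeps the aryl part of compound 2 and changes only the substituent attached to the core: a group of 6 heavy atoms (5 carbon, 1 oxygen; no ring) in place of a group of 10 heavy atoms (7 carbon, 1 nitrogen, 2 oxygen; no ring), on an aromatic carbon. The (pentan-3-yl)oxy group that enters carries an oxygen where compound 2 carried a nitrogen, and it is shorter than the group it replaces.

Among the compounds with values here, no measured pair shows this kind of exchange, so the size of the step is open. The expectation is that compound 4 gives a somewhat lower number than compound 2, a step of moderate size in this assay, although a result within the scatter would not be surprising. The estimate for compound 4 is 60 nM, with a range from 15 nM to 250 nM, which corresponds to an expected step of a 2.1-fold lower number from compound 2 to compound 4 (0.31 log units; beyond the scatter).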

Compound 4, inhibition constant: 1.9 nM
Estimate against measurement, compound 4: 32-fold (1.50 log units) above; the whole stated range lies above it.
By their numbers in this assay, from the lowest: compound 4; then compound 1; then compounds 3 and 2 (each within the scatter of the next).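

In this assay, placing the (pentan-3-yl)oxy group on the aromatic carbon next to the ring nitrogen, where compound 2 carries a group of 10 heavy atoms, gives a 65-fold lower number from compound 2 to compound 4 (1.81 log units; beyond the scatter). Within the data shown here, the earlier compounds differ from one another in more than one place, so they could not show how much this substituent alone matters; here the aryl part stays the same, and the single exchange at this position moves the number by a large step. Nothing available explains why the step is so large.

The exchange alters two things at once: oxygen replaces nitrogen as the atom attached to the core, and the group becomes shorter, so the contribution of each remains unresolved. A pentan-3-ylamino group on the same aryl part would help separate the two, while pairing the (pentan-3-yl)oxy group with the methylsulfonyl-bearing aryl part of compound 3 would test whether the step carries over to a different aryl part.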